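Methyl to Ethyl on the Aromatic Substituent

The source may report more compounds than this note shows. Statements on the series, on what has been measured and on what is new or still open speak of the compounds shown alone.

Two compounds share one core and differ in a small group on an aromatic ring. Compound 1 `CCOC(=O)C(=O)Nc1nc2ccc(NC(=O)c3cc4ccccc4[nH]3)cc2s1` carries a hydrogen there, and in a functional assay on MCF7 cells (Homo sapiens) for antiproliferative activity (on this read-out higher numbers stand for an effect only at larger amounts of compound and lower numbers for an effect already at smaller amounts), compound 1 gives 11200 nM. Compound 2 `CCOC(=O)C(=O)Nc1ccc2nc(NC(=O)c3cc4cc(C)ccc4[nH]3)sc2c1` carries a methyl there, and in this assay compound 2 gives 10100 nM. These two numbers lie within the scatter of each other, so no difference between them can be read. Compound 3 `CCOC(=O)C(=O)Nc1ccc2nc(NC(=O)c3cc4cc(CC)ccc4[nH]3)sc2c1` is not yet measured. It differs from compound 2 by methyl in place of hydrogen on a saturated chain carbon bound to an aromatic carbon; cut one bond further out, the change reads methyl to ethyl. Going by the values given here, no single-change step between measured compounds exists here. The change is small, and hydrogen against methyl between compound 1 and compound 2 stayed within the scatter, so the expected step of a 1.0-fold lower number from compound 2 to compound 3 (0.00 log units; within the scatter) is none beyond the scatter. For compound 3 the estimate in this assay is 10000 nM, with a range from 4000 nM to 25000 nM.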

Compound 3, half-maximal effective concentration: 25300 nM
Estimate against measurement, compound 3: 2.5-fold (0.40 log units) below, outside the stated range (above it).
By their numbers in this assay, from the lowest: compounds 2 and 1 (each within the scatter of the next); then compound 3.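

In this assay, going by these compounds alone, the change from methyl to ethyl gives a 2.5-fold higher number from compound 2 to compound 3 (0.40 log units; beyond the scatter) and so provides the first step at this position that rises above the usual noise of the measurement. The values of compound 1 and compound 2 alone had shown no readable difference, whereas this step shows that one more carbon on the saturated chain is enough to require a larger amount of compound for the same effect. Nothing in the data shown explains why the extra carbon has this effect.

A single step cannot show whether the number would keep rising with a longer chain such as propyl, or whether ethyl already marks a limit. On these data alone, it also remains open how this position would respond to a group of a different kind, such as an amine or a carboxylic acid.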